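A few compounds are considered here, and "the series" means these few. Any claim that something is new, unique, unknown or untested is made for them only; others in the source may bear on it.

Compound 1 `COc1nc(C)c2c(C)ncnc2c1C#N` is the smallest member of this set. In a functional assay on KB cells (Homo sapiens) for cytotoxicity, read by MTT assay, with a stated time of 3 days (on this read-out higher numbers stand for weaker inhibition and lower numbers for stronger inhibition), compound 1 gives only a limit, > 50000 nM. Compound 2 `C=C1c2c(C)nc(OC)c(C#N)c2N=CN1CC` adds to the shared core a further ring that carries an ethyl group on an amine nitrogen. In this assay compound 2 also reaches only a limit, > 50000 nM. Compound 3 `C=C1c2c(C)nc(OC)c(C#N)c2N=CN1Cc1ccco1` carries a (furan-2-yl)methyl group in that place instead. In this assay compound 3 likewise gives only a limit, > 50000 nM. The step that the two limits leave unreadable from compound 2 to compound 3 therefore cannot be read, because the limit of > 50000 nM in this assay, at which 3 of the 3 values shown sit, shows that every value so far is a limit; on the numbers shown compound 3 simply stands at that limit together with the other two.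

Compound 4 `C=C1c2c(C)nc(OC)c(C#N)c2N=CN1Cc1ccc(C)cc1` differs from compound 3 by 4-methylphenyl in place of furan-2-yl on a saturated chain carbon bound to an amine nitrogen in a ring. Among the measured compounds shown here, the only measured step that touches the same place is the unreadable one just described, so there is no measured basis for expecting a change in this assay beyond the scatter, in either direction. Compound 4 is therefore expected to finish at the same limit, 50000 nM, with a range from 20000 nM to 50000 nM. The step of a number no higher from compound 3 to compound 4 (the limit leaves the size open) that this estimate means is expected to be none at all.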

Compound 4, half-maximal inhibitory concentration: 480 nM
Compound 4: middle estimate off by 100-fold (2.02 log units), on the high side; the whole stated range lies above it.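

In this assay, among the compounds shown here, replacing the (furan-2-yl)methyl group with 4-methylbenzyl on the ring amine nitrogen gives an at least 100-fold lower number from compound 3 to compound 4 (2.01 log units; beyond the scatter), which shows that this place can strongly change the read-out, something the earlier compounds could not reveal. Compared with the ethyl group of compound 2, where 4-methylphenyl stands in place of methyl on the saturated chain carbon, the result is an at least 100-fold lower number from compound 2 to compound 4 (2.01 log units; beyond the scatter), so the shared core with a small ethyl or a (furan-2-yl)methyl group stays at the limit, while the 4-methylbenzyl group brings a measurable value. Both steps give only a minimum size and not an exact one: the limit of > 50000 nM in this assay, at which 3 of the 4 values shown sit.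

Compound 4 differs from compound 3 in both its ring and the methyl group on that ring, so the compounds shown cannot tell whether the six-membered carbon ring alone is enough or the methyl group is also needed, and a plain benzyl group would separate the two. Going by these compounds, how other groups at this place would behave, such as 4-methoxybenzyl or a longer chain ending in an amine, also remains open.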